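Swapping ethyl for fluoro in compound 3

A few compounds are considered here, and "the series" means these few. Any claim that something is new, unique, unknown or untested is made for them only; others in the source may bear on it.

Results so far in a functional assay on HeLa cells (Homo sapiens) for inhibition, read by CCK-8 assay, with a stated time of 72 h; on this read-out lower numbers stand for stronger inhibition and higher numbers for weaker inhibition
compound 1 `O=C(/C=C/c1cccnc1)NCCCCCCCc1cccc(S(=O)(=O)Nc2ccccc2)c1` gives 598 nM
compound 2 `Cc1cccc(NS(=O)(=O)c2cccc(CCCCCCNC(=O)/C=C/c3cccnc3)c2)c1` gives 65.8 nM
compound 3 `CCc1ccc(NS(=O)(=O)c2cccc(CCCCCCNC(=O)/C=C/c3cccnc3)c2)cc1` gives 132 nM

Compound 3 lies within the usual scatter of compound 2, while compound 1 stands clearly higher. Compound 4 `O=C(/C=C/c1cccnc1)NCCCCCCc1cccc(S(=O)(=O)Nc2ccc(F)cc2)c1` replaces the 4-ethylphenyl of compound 3 with 4-fluorophenyl (fluoro in place of ethyl on an aromatic carbon). Within the data shown here, the one measured step on this ring (a 2.0-fold higher number from compound 2 to compound 3 (0.30 log units; within the scatter)) put 4-ethylphenyl in place of 3-methylphenyl and stayed within the scatter. Among the measured compounds shown here, no measured compound carries a fluoro group, so that step is only a loose guide. No step beyond the scatter is therefore expected in this assay, and no direction can be favoured. The estimated step is small (a 1.2-fold lower number from compound 3 to compound 4 (0.08 log units; within the scatter)). The estimate for compound 4 is 110 nM, with an expected range from 40 nM to 300 nM.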

Compound 4, half-maximal inhibitory concentration: 99.9 nM
Compound 4: the middle estimate sits 1.1-fold (0.04 log units) above what was measured; the range from low to high includes it.
By their numbers in this assay, from the lowest: compounds 2, 4 and 3 (each within the scatter of the next); then compound 1.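

Fluoro in place of ethyl gives a 1.3-fold lower number from compound 3 to compound 4 (0.12 log units; within the scatter) in this assay and so this ring position holds its activity with either group. Set against the 3-methylphenyl ring, the 4-fluorophenyl ring gives a 1.5-fold higher number from compound 2 to compound 4 (0.18 log units; within the scatter) and all three substituted rings in compounds 2, 3 and 4 now lie within the scatter of one another. Nothing available explains this tolerance. The compounds shown leave open whether an amine or a carboxylic acid on this same aromatic carbon would stay within that range. They also leave open whether a second fluoro group on the ring would do so.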